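The compounds below may be only part of what the source reports. "The series", "measured", "known", "first", "only" and "open" are said of these compounds alone.

In a functional assay on MT2 cells (Homo sapiens) for cytotoxicity (on this read-out higher numbers stand for lower toxicity in this test and lower numbers for higher toxicity in this test), compound 1 `CC1=CN([C@H]2C[C@H](O)[C@@H](COC(=O)C[C@@]3(C)C[C@@](C)(O)CO3)O2)C(=O)NC1` gives > 1000000 nM, which is a limit of the assay and not a number. Among the measured compounds shown here, compound 2 `Cc1cn([C@H]2C[C@H](O[Si](C)(C)C(C)(C)C)[C@@H](COC(=O)CC3(C)CC(C)(O)CO3)O2)c(=O)[nH]c1=O`, the only other compound tested, gives 200000 nM; 200000 nM (2 entries). Compound 3 `Cc1cn([C@H]2C[C@H](O)[C@@H](COC(=O)C[C@@]3(C)C[C@@](C)(O)CO3)O2)c(=O)[nH]c1=O` differs from compound 1 in one place, on a saturated ring carbon of a five-membered non-aromatic ring with 1 oxygen, next to the ring oxygen: a group of 9 heavy atoms (5 carbon, 2 nitrogen, 2 oxygen; one six-membered aromatic ring with 2 hetero atoms) in place of a group of 8 heavy atoms (5 carbon, 2 nitrogen, 1 oxygen; one six-membered non-aromatic ring with 2 hetero atoms), on a saturated ring carbon. For the measured compounds named here, no measured step bears on this change, so only a modest shift toward higher toxicity is expected, with the estimated at least 1.6-fold lower number from compound 1 to compound 3 (0.22 log units; that floor lies within the scatter) in this assay. Compound 3 is expected to give about 600000 nM, within an estimated range of 200000 nM to 1500000 nM.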

Compound 3, half-maximal cytotoxic concentration: > 1000000 nM
Compound 3 ended at the assay's limit; the forecaster's own chance of this, stated with the estimate: 50%; at least 1.6-fold (0.22 log units) between middle value and limit.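

No step can be read between compound 1 and compound 3, because each result is a limit of the assay and not a number: the limit of > 1000000 nM in this assay, at which 2 of the 3 values shown sit. The compounds shown leave open whether exchanging these two groups changes the result in this assay.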